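A few compounds are considered here, and "the series" means these few. Any claim that something is new, unique, unknown or untested is made for them only; others in the source may bear on it.

Working notes on the series. Two members carry numbers in a functional assay on U-87MG ATCC cells for antiproliferative activity against U-87 MG (Homo sapiens), read by MTT assay, with a stated time of 48 h, tested at 100 uM; on this read-out higher numbers stand for a weaker effect at the one concentration tested and lower numbers for a stronger effect. Compound 1 `COc1cccc(-c2nc(SCC(=O)c3sc(-c4ccccc4)nc3C)[nH]c(=O)c2C#N)c1` gives 21.8% in this assay. Compound 2 `Cc1nc(-c2ccc(Cl)cc2)sc1C(=O)CSc1nc(-c2ccc(Cl)c(Cl)c2)c(C#N)c(=O)[nH]1` gives 36.5% and stands highest of the two numbers, its nearest neighbour being compound 1 at a value lower by an amount beyond the scatter; the two differ in more than one place, so only their values are compared. Compound 3 `Cc1nc(-c2ccccc2)sc1C(=O)CSc1nc(-c2ccc(Cl)c(Cl)c2)c(C#N)c(=O)[nH]1` is unmeasured. It differs from compound 2 by hydrogen in place of chloro on an aromatic carbon. For the measured compounds named here, with no single-change step available, the expected step from compound 2 to compound 3 is a number 4.5 percentage points lower from compound 2 to compound 3 (within the scatter), small and not clearly beyond the scatter. Compound 3 is therefore estimated at 32%, within 20% to 45%.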

Compound 3, a percentage reported as activity, at one concentration (the size of the read-out at that concentration, not a potency): 24.4%
For compound 3 the middle estimate is 7.6 percentage points above the measured one; the measured number falls inside the stated range.
By their numbers in this assay, from the lowest: compounds 1 and 3 (each within the scatter of the next); then compound 2.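

In this assay, for the compounds shown here, the change from 4-chlorophenyl to phenyl gives the only single-change step at this position: a number 12.1 percentage points lower from compound 2 to compound 3 (beyond the scatter), a modest gain in effect on removing the chloro. Replacing 3-methoxyphenyl with 3,4-dichlorophenyl on the other aromatic carbon gives a number 2.6 percentage points higher from compound 1 to compound 3 (within the scatter), so these two groups are not told apart here. No data on hand offer a reason for either step.

As far as these compounds go, whether a fluoro, methoxy or amine at this position would match hydrogen or chloro stays open. So does whether the chloro step holds with 3-methoxyphenyl in place of 3,4-dichlorophenyl.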